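The source may report more compounds than this note shows. Statements on the series, on what has been measured and on what is new or still open speak of the compounds shown alone.

Measured in a functional assay on A549 cells (Homo sapiens) for inhibition, read by MTT assay, with a stated time of 48 h; on this read-out lower numbers stand for stronger inhibition and higher numbers for weaker inhibition:
- compound 1 `COc1ccc(N(C)c2nc(C)nc3ccccc23)cc1C(=O)OCC[Se]C#N`: 353 nM
- compound 2 `COc1ccc(N(C)c2nc(C)nc3ccccc23)cc1C(=O)OCCCC[Se]C#N`: 155 nM

Compound 2 has the lower of the two numbers in this assay, which makes it the stronger inhibitor of this pair. The next compound to be tested is compound 3 `COc1ccc(N(C)c2nc(C)nc3ccccc23)cc1C(=O)OCCCCC[Se]C#N`. It differs from compound 2 by a group of 4 heavy atoms (2 carbon, 1 nitrogen, 1 selenium; no ring) in place of a group of 3 heavy atoms (1 carbon, 1 nitrogen, 1 selenium; no ring), on a saturated chain carbon, four bonds along the chain from an oxygen next to a carbonyl group, so the same chain grows once more. Among the compounds with values here, only one measured step bears on this change: a 2.3-fold lower number from compound 1 to compound 2 (0.36 log units; beyond the scatter). That step was modest, and it lengthened the chain by more than the new change does. A single step cannot show a trend, and the gain could stop at any chain length. A small further fall is therefore the most that seems reasonable. The expected step is a 1.3-fold lower number from compound 2 to compound 3 (0.11 log units; within the scatter), which may not clear the usual scatter. For compound 3 the estimated value is 120 nM, with an expected range of 50 nM to 300 nM.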

Compound 3, half-maximal inhibitory concentration: 592 nM
Compound 3: middle estimate off by 4.9-fold (0.69 log units), on the low side, outside the stated range (above it).
By their numbers in this assay, from the lowest: compound 2; then compounds 1 and 3 (each within the scatter of the next).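

In this assay, the gain from lengthening the chain does not continue, and one further step reverses it, with a 3.8-fold higher number from compound 2 to compound 3 (0.58 log units; beyond the scatter). The longest chain also cannot be told apart from the shortest, with a 1.7-fold higher number from compound 1 to compound 3 (0.22 log units; within the scatter), so this position shows a turning point at compound 2 rather than a steady trend, and compound 2 is the strongest inhibitor of the three. No measured evidence here accounts for this turn.

The compounds shown leave open whether a chain of a length falling between those of compound 1 and compound 2 would do better still, and whether a longer chain would keep losing ground. They also leave open how an amine would behave at this position in place of the selenium and nitrile.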